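This account rests on a few compounds, and the source may have more. Where it says the series, first, only, none or still open, it means among the compounds named here.

Four compounds share one core, a pyridine carboxamide joined through an ether oxygen to a phenyl ring that carries an unsaturated ketone. Compound 1 `CNC(=O)c1cc(Oc2ccc(/C=C/C(=O)c3ccc([N+](=O)[O-])cc3)cc2)ccn1` and compound 3 `CNC(=O)c1cc(Oc2ccc(C(=O)/C=C/c3ccc(OC)c(OC)c3OC)cc2)ccn1` belong to the set, but in a functional assay on A549 cells (Homo sapiens) for cytotoxicity, read by MTT assay, with a stated time of 72 h (a lower number here means a stronger inhibitor, a higher number a weaker inhibitor), compound 1 gives "not determined" (no result reported) and compound 3 gives "not determined" (no result reported), so neither can be placed. Within the data shown here, compound 2 `CNC(=O)c1cc(Oc2ccc(C(=O)/C=C/c3ccc(C#N)cc3)cc2)ccn1` is therefore the only anchor: in this assay compound 2 gives 26400 nM, a weak result, and with nothing else measured it is also the whole of what is known about this series so far.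

Compound 4 `CNC(=O)c1cc(Oc2ccc(C(=O)/C=C/c3ccc(Br)cc3)cc2)ccn1` is the next to be tested, and it differs from compound 2 in a single place: bromo in place of cyano on an aromatic carbon. The cyano leaves and a bromo enters, and the rest of the molecule is unchanged.

Among the measured compounds shown here, no pair of measured compounds shows how this assay answers such a swap, so the expectation rests on compound 2 alone. The step from compound 2 to compound 4 is expected to be small, a 1.2-fold lower number from compound 2 to compound 4 (0.08 log units; within the scatter), not clearly beyond the usual scatter in either direction. On that basis compound 4 is estimated at 22000 nM, with a range from 8000 nM to 60000 nM.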

Compound 4, half-maximal inhibitory concentration: > 50000 nM
Compound 4 gave a limit, no number; the forecaster's own chance of this, stated with the estimate: 20%; middle value at least 2.2-fold (0.35 log units) away from the limit.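

Among these compounds, this is the first step that can be read: on the 4-cyanophenyl ring, para to a large group, putting a bromo in place of the cyano gives an at least 1.8-fold higher number from compound 2 to compound 4 (0.27 log units; that floor lies within the scatter). In this assay compound 4 gives > 50000 nM, which is a limit of the assay and not a number. The swap therefore shows no sign of a lower number at this position, yet the true size of the step stays unknown, and it cannot be called clearly beyond the usual scatter, because the result for compound 4 is a limit: the limit of > 50000 nM in this assay, at which 1 of the 4 values shown sits.

Among the compounds shown here, compound 1 and compound 3 have no reported result, so no steps involving them can be read, and the effect of changes elsewhere in the shared core remains unknown. For the compounds shown here, with only cyano and bromo to compare at this position, it remains open whether a different group, such as an amine or a carboxylic acid, would give a number clearly lower than the one for compound 2, 26400 nM.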